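The source may hold more compounds than are shown below. What is called first, only, known or untested is meant among the compounds shown, and "the series" means these compounds.

Measured compounds:
- compound 1 `Oc1ccc(Cn2cc[nH]c2=S)cc1C(F)(F)F`: 120000 nM
- compound 2 `S=c1[nH]ccn1Cc1c(Cl)cccc1Cl`: 708000 nM
- compound 3 `S=c1[nH]ccn1Cc1cccc(Cl)c1Cl`: 52500 nM

These three compounds were tested in an assay on isolated protein for inhibition of Dopamine beta-hydroxylase (Rattus norvegicus); a lower number here means a stronger inhibitor, a higher number a weaker inhibitor. Among them compound 1 gives the second highest number of the three. Its nearest neighbour is compound 3, whose number is lower by a margin beyond the scatter, and the furthest is compound 2, whose number is higher by a margin also beyond the scatter. No pair among these three differs in a single place, so no single step between measured compounds is available.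

Compound 4 `Cc1cc(Cn2cc[nH]c2=S)ccc1O` has not yet been measured. It differs from compound 1 in one place: methyl in place of trifluoromethyl on an aromatic carbon. The change sits on the aromatic carbon ortho to the hydroxy group.

Among the compounds with values here, with no comparable step among the measured compounds to lean on, the expected step from compound 1 to compound 4 in this assay is estimated to be small, essentially none beyond the scatter, a 1.2-fold lower number from compound 1 to compound 4 (0.08 log units; within the scatter). Compound 4 is therefore expected to give about 100000 nM, within a range from 25000 nM to 400000 nM.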

Compound 4, half-maximal inhibitory concentration: 49000 nM
Compound 4: the middle estimate sits 2.0-fold (0.31 log units) above what was measured; the range from low to high includes it.
By their numbers in this assay, from the lowest: compounds 4 and 3 (each within the scatter of the next); then compound 1; then compound 2.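

In this assay, within the data shown here, this is the first step in the set that changes a single place, and it gives a reading for the aromatic carbon ortho to a hydroxy group: methyl in place of trifluoromethyl gives a 2.4-fold lower number from compound 1 to compound 4 (0.39 log units; beyond the scatter). The step is modest but beyond the scatter, so the number responds to this change, and trifluoromethyl is not needed at this carbon for a number as low as that of compound 1. Nothing measured here accounts for the step, which stands as an observation only.

Among these compounds, with only two groups compared at this carbon, it remains open how a chlorine, an ethyl group or a plain hydrogen there would read. Also open, as far as these compounds go, is how a methoxy group in place of the hydroxy group would alter the number.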